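The compounds below may be only part of what the source reports. "The series", "measured", "known", "first", "only" and "open" are said of these compounds alone.

In a functional assay on U-373MG ATCC cells for cytotoxicity against U373 MG (Homo sapiens), read by colorimetric assay and MTT assay (a higher number here means a weaker inhibitor, a lower number a stronger inhibitor), compound 3 (`COc1ccc(-c2cc3c(OC)cc(OC)cc3n(CC(=O)O)c2=O)cc1`) gives 10000 nM, level with compound 1 (`COc1ccc(-c2cc3c(OC)cc(OC)cc3n(CC#N)c2=O)cc1`) at 10000 nM and compound 2 (`COc1ccc(-c2cc3c(OC)cc(OC)cc3n(CC(=O)OCc3ccccc3)c2=O)cc1`) at 10000 nM. Compound 4 (`CCN(CC)C(=O)CCn1c(=O)c(-c2ccc(OC)cc2)cc2c(OC)cc(OC)cc21`) differs from compound 3 in one place: (diethylcarbamoyl)methyl in place of carboxy on a saturated chain carbon bound to an aromatic nitrogen. Here (diethylcarbamoyl)methyl stands in place of carboxy on a saturated chain carbon bound to an aromatic nitrogen. Three measured steps at this place bear on the change: no change at the digits printed from compound 1 to compound 2 (within the scatter), no change at the digits printed from compound 1 to compound 3 (within the scatter) and no change at the digits printed from compound 2 to compound 3 (within the scatter). None goes beyond the scatter, but no amide has been measured here, so the range stays wide. No step beyond the scatter is expected in this assay, and the expected step is no change at the digits printed from compound 3 to compound 4 (within the scatter). Compound 4 is estimated at 10000 nM, with an expected range of 3000 nM to 20000 nM.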

Compound 4, half-maximal inhibitory concentration: 10000 nM
Beside the measured number, compound 4's estimate shows no gap at the digits printed; low and high end bracket the measured number.
By their numbers in this assay, from the lowest: compounds 1, 2, 3 and 4 (each within the scatter of the next).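

In this assay compound 4, the only amide shown at this place, gives 10000 nM, and its steps from the acid (no change at the digits printed from compound 3 to compound 4 (within the scatter)), the benzyloxycarbonyl compound (no change at the digits printed from compound 2 to compound 4 (within the scatter)) and the nitrile (no change at the digits printed from compound 1 to compound 4 (within the scatter)) stay flat. On a saturated chain carbon bound to an aromatic nitrogen, 8 heavy atoms with 0 hydrogen-bond donors thus read the same as carboxy with 3 heavy atoms and 1 donor. No evidence at hand offers a cause for this flat reading.

As far as these compounds go, whether a basic amine at this place, or a change on the shared core, would give any step beyond the scatter remains open.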